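The compounds below may be only part of what the source reports. "The series", "measured", "known", "first", "only" and "open" are said of these compounds alone.

Measured in a functional assay on PC-3 cells (Homo sapiens) for cytotoxicity, read by MTT assay, with a stated time of 24 h; a lower number here means a stronger inhibitor, a higher number a weaker inhibitor:
- compound 1 `Cc1ccc(/C=C2\CN(Cc3cn(Cc4ccc(F)cc4)nn3)C/C(=C\c3ccc(C)cc3)C2=O)cc1`: 65600 nM
- compound 2 `Cc1ccc(/C=C2\CN(Cc3cn(Cc4cccc(Cl)c4)nn3)C/C(=C\c3ccc(C)cc3)C2=O)cc1`: 29300 nM

Within the data shown here, compound 2, at 29300 nM, holds the lower of the two numbers so far. Compound 3 `Cc1ccc(/C=C2\CN(Cc3cn(Cc4ccccc4F)nn3)C/C(=C\c3ccc(C)cc3)C2=O)cc1` has not yet been measured and differs from it in one place: 2-fluorophenyl in place of 3-chlorophenyl on a saturated chain carbon bound to an aromatic nitrogen. In words, 2-fluorophenyl stands in place of 3-chlorophenyl on a saturated chain carbon bound to an aromatic nitrogen.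

Among the measured compounds shown here, only one measured step bears on this: a 2.2-fold lower number from compound 1 to compound 2 (0.35 log units; beyond the scatter), a modest change, with 3-chlorophenyl in place of 4-fluorophenyl at that same place. Compound 3 again carries a fluorophenyl, as compound 1 does, though a different one. For the measured compounds named here, a small rise in this assay is therefore expected, no larger than that step and possibly within the scatter. The expected change is a 1.5-fold higher number from compound 2 to compound 3 (0.19 log units; within the scatter). For compound 3 the estimate is 45000 nM, with an expected range from 20000 nM to 100000 nM.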

Compound 3, half-maximal inhibitory concentration: 8800 nM
For compound 3 the middle estimate is 5.1-fold (0.71 log units) above the measured one; the measured number lies below the stated range.
By their numbers in this assay, from the lowest: compound 3; then compound 2; then compound 1.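

In this assay, the two fluorophenyl compounds now stand at opposite ends of the order, so a fluorine on this ring does not by itself settle the number: 2-fluorophenyl in place of 4-fluorophenyl gives a 7.5-fold lower number from compound 1 to compound 3 (0.87 log units; beyond the scatter). Putting 2-fluorophenyl in place of 3-chlorophenyl gives a 3.3-fold lower number from compound 2 to compound 3 (0.52 log units; beyond the scatter), but this step changes both the halogen and its place on the ring, and the two changes cannot be told apart from it. Nothing measured here accounts for either step.

The compounds shown leave open how an unsubstituted phenyl or a methoxyphenyl would compare at this place, and whether 2-chlorophenyl would track 2-fluorophenyl. They also leave open what a longer chain between the ring and the aromatic nitrogen would do.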